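The compounds below may be only part of what the source reports. "The series", "measured", "known", "first", "only" and "open" are said of these compounds alone.

Compounds measured so far:

- Compound 1, `Cn1ncc2c(-c3ccccc3)cc(NNC(=O)Nc3cc(Cl)nc(Cl)c3)nc21`: 6240 nM
- Compound 2, `Cn1ncc2c(-c3ccc(F)cc3)cc(NNC(=O)Nc3cc(Cl)cc(Cl)c3)nc21`: 39100 nM
- Compound 3, `CCCOc1cc(NC(=O)NNc2cc(-c3ccc(OC)cc3)c3cnn(C)c3n2)cc(Cl)n1`: 33300 nM

All three were tested in a functional assay on HCT-116 cells (Homo sapiens) for cytotoxicity, read by MTT assay, with a stated time of 48 h, in the presence of a further agent that is not named here; on this read-out higher numbers stand for an effect only at larger amounts of compound and lower numbers for an effect already at smaller amounts. Among them compound 1 has the lowest number, with 6240 nM. The nearest to it is compound 3, whose value is 33300 nM, and the furthest is compound 2, whose value is 39100 nM; both of these gaps lie beyond the usual scatter, so compound 1 stands apart as the most active of the three in this assay.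

The step under consideration goes from compound 1 to compound 4, `CC(C)c1cc(NNC(=O)Nc2cc(Cl)nc(Cl)c2)nc2c1cnn2C`, which has not yet been tested. The change is isopropyl in place of phenyl on an aromatic carbon. Within the data shown here, no pair of measured compounds differs in one place only, so there is no comparable step to lean on; the three measured compounds differ from one another in several places at once.

With nothing directly comparable, the expectation is cautious. Replacing the phenyl by the smaller isopropyl is expected to raise the number somewhat, on the order of a step that may just exceed the scatter, giving for compound 4 an estimated 14000 nM with a range from 4000 nM to 50000 nM; the expected step is a 2.2-fold higher number from compound 1 to compound 4 (0.35 log units; beyond the scatter).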

Compound 4, half-maximal effective concentration: 17200 nM
Estimate against measurement, compound 4: 1.2-fold (0.09 log units) below; the measured number falls inside the stated range.
By their numbers in this assay, from the lowest: compound 1; then compounds 4, 3 and 2 (each within the scatter of the next, the first and the last beyond it).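

In this assay, compounds 1 and 4 give the first reading of a single change among the compounds shown: isopropyl replaces phenyl on the aromatic carbon opposite the ring nitrogen, and the result is a 2.8-fold higher number from compound 1 to compound 4 (0.44 log units; beyond the scatter), a modest step beyond the scatter. This shows that the position is not indifferent to its group, since exchanging the six-carbon aromatic ring for the three-carbon isopropyl, which has no ring, weakens the effect in this assay, though only modestly. No measurement at hand explains why the number rises with this change.

The compounds shown leave open whether the step follows from losing the aromatic ring or from the particular group that enters, a question that a cyclopropyl, a methyl, a longer chain such as butyl or an amine on the same carbon could help to settle. From the compounds shown here alone, it also remains open whether the same step would appear with a phenyl carrying fluorine or methoxy, as the other compounds do, since neither has an isopropyl counterpart here.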